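A hydroxymethyl group enters the series at compound 4

The source may report more compounds than this note shows. Statements on the series, on what has been measured and on what is new or still open speak of the compounds shown alone.

In a physicochemical assay for lipophilicity, read by HPLC, at pH 7.5 (on this read-out lower numbers stand for lower lipophilicity and higher numbers for higher lipophilicity), compound 3 (`CC[C@@H](Nc1c(C#N)c(-c2ccc(-c3ccc(F)cc3)cc2)nc2cnccc12)C(N)=O`) gives 2.7 as its reading. Compound 1 (`CC[C@@H](Nc1c(C#N)c(-c2ccc(-c3cccc(C)c3)cc2)nc2cnccc12)C(N)=O`) reads 3 and compound 2 (`CC[C@@H](Nc1c(C#N)c(-c2ccc(-c3cccc(C)c3F)cc2)nc2cnccc12)C(N)=O`) reads 3 on the same scale, and all three readings lie within the scatter of one another. Compound 4 (`CC[C@@H](Nc1c(C#N)c(-c2ccc(-c3cccc(CO)c3)cc2)nc2cnccc12)C(N)=O`) has not yet been measured. Its difference from compound 3 is 3-(hydroxymethyl)phenyl in place of 4-fluorophenyl on an aromatic carbon and amounts to 3-(hydroxymethyl)phenyl in place of 4-fluorophenyl on an aromatic carbon.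

The measured steps at this place are small. They are a number 0.30 log units lower from compound 1 to compound 3 (within the scatter) and a number 0.30 log units lower from compound 2 to compound 3 (within the scatter) while the fluoro exchange shows no change at the digits printed from compound 1 to compound 2 (within the scatter) as its outcome. For the measured compounds named here, none of these steps brings in a hydrogen-bond donor, and no measured compound carries a hydroxymethyl group. They therefore offer only a weak guide, and the added donor and acceptor lead to the expectation of a lower number. A step of a number 0.50 log units lower from compound 3 to compound 4 (beyond the scatter) is what is expected here. Compound 4 is estimated at 2.2 with an expected range from 1.8 to 2.6 once measured.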

Compound 4, distribution coefficient: 2
Estimate against measurement, compound 4: 0.20 log units above; the range from low to high includes it.
By their numbers in this assay, from the lowest: compound 4; then compounds 3, 1 and 2 (each within the scatter of the next).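

In this assay, for the compounds shown here, this place had so far given only steps within the scatter, but the exchange for 3-(hydroxymethyl)phenyl goes beyond it, with a number 0.70 log units lower from compound 3 to compound 4 (beyond the scatter) and a number 1.00 log units lower from compound 2 to compound 4 (beyond the scatter). The narrowest comparison is hydroxy in place of hydrogen on a saturated chain carbon bound to an aromatic carbon, which alone gives a number 1.00 log units lower from compound 1 to compound 4 (beyond the scatter) and so shows that this single exchange is enough to move the reading beyond the scatter. Nothing in the available data accounts for the size of these steps.

On these data alone, whether an aminomethyl group or a carboxylic acid at this place would give a step of similar size remains open. So does whether a methoxymethyl group or a longer chain such as 2-hydroxyethyl would read like compound 4 or nearer compound 1.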